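The source may hold more compounds than are shown below. What is called first, only, known or untested is meant among the compounds shown, and "the series" means these compounds.

Compound 1 `CCCN(CC1CC1)c1cc(C)nc2c(-c3ccc(Cl)cc3Cl)nn(C)c12` and compound 2 `Cc1cc(N(CC(C)C)CC2CC2)c2c(n1)c(-c1ccc(Cl)cc1Cl)nn2C` share one core and differ only on the chain carried by the ring nitrogen. For the measured compounds named here, in an assay on HEK293 cells for displacement of a labelled ligand from corticotropin-releasing factor receptor 1 (Homo sapiens) (a lower number here means a stronger inhibitor, a higher number a weaker inhibitor), compound 1 gives 1.7 nM, and compound 2 gives 3.7 nM, the higher of the two numbers known; the change from one to the other is a 2.2-fold higher number from compound 1 to compound 2 (0.34 log units; beyond the scatter), a methyl in place of hydrogen on a saturated chain carbon bound to two saturated chain carbons. Compound 3 `CCCCCN(CC1CC1)c1cc(C)nc2c(-c3ccc(Cl)cc3Cl)nn(C)c12` is the next member, differing from compound 2 by butyl in place of isopropyl on a saturated chain carbon bound to a nitrogen on an aromatic ring, which read one bond further out is isobutyl to pentyl. Going by the values given here, the only step that bears on it, the one from compound 1 to compound 2, was modest, and it concerns branching rather than chain length, so the present change of branch to straight longer chain has no direct precedent. A modest step, direction uncertain, is therefore expected in this assay, a 1.2-fold lower number from compound 2 to compound 3 (0.09 log units; within the scatter). For compound 3 the estimated value is 3 nM, between 1.2 nM and 8 nM.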

Compound 3, inhibition constant: 1.5 nM
Estimate against measurement, compound 3: 2.0-fold (0.30 log units) above, and the stated range covers the measured number.
By their numbers in this assay, from the lowest: compounds 3 and 1 (each within the scatter of the next); then compound 2.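

In this assay, for the compounds shown here, a straight chain longer than the one in compound 2 is tolerated, and the number falls back (a 2.5-fold lower number from compound 2 to compound 3 (0.39 log units; beyond the scatter)), so isobutyl to pentyl at this place is not a loss. Compound 3 also stands level with compound 1 (a 1.1-fold lower number from compound 1 to compound 3 (0.05 log units; within the scatter)), which shows that ethyl in place of hydrogen on a saturated chain carbon, three bonds along the chain from a nitrogen on an aromatic ring, leaves the number where it was, and that among these three compounds only the branched isobutyl chain of compound 2 stands apart. No measurement available here accounts for this difference between branched and straight chains.

Going by these compounds, whether the tolerance extends to a hexyl or longer chain, or to a chain ending in a hydroxyl or an amine, stays open. The cyclopropylmethyl group is the same in all three compounds, so what it contributes cannot be read from them.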